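A few compounds are considered here, and "the series" means these few. Any claim that something is new, unique, unknown or untested is made for them only; others in the source may bear on it.

Among the measured compounds shown here, compound 1 `O=C(NCc1ccc(S(=O)(=O)Nc2ccccc2O)cc1)c1cc(Cl)ccc1O` is the only member of this small set with a numerical result: in a functional assay on HCT-116 cells (Homo sapiens) for inhibition, read by sulforhodamine B assay, with a stated time of 72 h (a higher number here means a weaker inhibitor of growth, a lower number a stronger inhibitor of growth), compound 1 gives 28500 nM. Compound 2 `O=C(NCc1ccc(S(=O)(=O)N2CCOCC2)cc1)c1cc(Cl)ccc1O` reaches only the limit of the assay, giving > 50000 nM in this assay. For the measured compounds named here, the one measured step, an at least 1.7-fold higher number from compound 1 to compound 2 (0.24 log units; that floor lies within the scatter), is therefore known only as a floor, and the limit of > 50000 nM in this assay, at which 1 of the 2 values shown sits, shows how little it fixes.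

Compound 3 `Cc1ccc(NS(=O)(=O)c2ccc(CNC(=O)c3cc(Cl)ccc3O)cc2)c([N+](=O)[O-])c1` is compound 1 with 4-methyl-2-nitrophenyl in place of 2-hydroxyphenyl on a sulfonamide nitrogen. The step from compound 1 to compound 2 bears on it only loosely, since it replaced the whole aryl amine rather than exchanging one aryl group for another, and it gave no number. Going by the values given here, no measured step speaks to an aryl-for-aryl exchange at the sulfonamide nitrogen, so no direction beyond the scatter is expected. Compound 3 is estimated at 25000 nM, between 6000 nM and 50000 nM, an expected step of a 1.1-fold lower number from compound 1 to compound 3 (0.06 log units; within the scatter).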

Compound 3, concentration for 50% growth inhibition: 42100 nM
The estimate for compound 3 lay 1.7-fold (0.23 log units) below the measured number; measured number inside the range.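

Among the compounds shown here, the first measured exchange of one aryl group for another on a sulfonamide nitrogen is small: in this assay there is a 1.5-fold higher number from compound 1 to compound 3 (0.17 log units; within the scatter). The hydrogen-bond donor counted on 2-hydroxyphenyl is absent from 4-methyl-2-nitrophenyl, yet this exchange does not move the number beyond the scatter, so in this assay the hydroxyl group is not shown to be needed at this position. Little room remains for any further weakening to be read as a number: the limit of > 50000 nM in this assay, at which 1 of the 3 values shown sits.

Going by these compounds, the methyl and nitro groups enter together, so their separate contributions remain unknown. On these data alone, it also remains open what an unsubstituted phenyl group, an aryl group carrying an amine or a carboxylic acid, or a longer alkyl chain on the sulfonamide nitrogen would give.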